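Removing an acetyl group from compound 3

This account rests on a few compounds, and the source may have more. Where it says the series, first, only, none or still open, it means among the compounds named here.

Measured so far in a functional assay on MCF7 cells (Homo sapiens) for antiproliferative activity; on this read-out lower numbers stand for stronger inhibition and higher numbers for weaker inhibition:
- Compound 1 (`C=CCc1cc(C(=O)Nc2cc3ccc(OC4CCN(C)CC4)c(C)c3oc2=O)ccc1O`): 2170 nM
- Compound 2 (`Cc1c(OC2CCN(C)CC2)ccc2cc(NC(=O)c3ccc(O)c(Cl)c3)c(=O)oc12`): 1480 nM
- Compound 3 (`COc1cccc(-c2cc(C(=O)Nc3cc4ccc(OC5CCN(C)CC5)c(C)c4oc3=O)ccc2OC(C)=O)c1`): 910 nM

Compound 3 at 910 nM sits within the usual scatter of compound 2 at 1480 nM and has a lower number than compound 1 at 2170 nM by more than the scatter. The next molecule, compound 4 (`COc1cccc(-c2cc(C(=O)Nc3cc4ccc(OC5CCN(C)CC5)c(C)c4oc3=O)ccc2O)c1`), turns acetoxy to hydroxy, and the counted difference is hydrogen in place of acetyl on an oxygen on an aromatic ring with nothing else altered. Among the compounds with values here, no measured pair shows this change directly. Within the data shown here, the only measured step, a 1.5-fold lower number from compound 1 to compound 2 (0.17 log units; within the scatter), is a different change, chloro in place of allyl on an aromatic carbon, so it offers only a loose guide. Compound 1 and compound 2 also carry a hydroxy, but they differ from compound 4 elsewhere too. No step beyond the scatter is therefore expected in this assay for this change. The expected step is a 1.2-fold higher number from compound 3 to compound 4 (0.08 log units; within the scatter) and it carries real uncertainty. For compound 4 the estimate is 1100 nM with an expected range from 450 nM to 2600 nM around it.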

Compound 4, half-maximal inhibitory concentration: 810 nM
Estimate against measurement, compound 4: 1.4-fold (0.13 log units) above, within the range that was stated.
By their numbers in this assay, from the lowest: compounds 4, 3, 2 and 1 (each within the scatter of the next, the first and the last beyond it).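

In this assay, taking the acetyl off the oxygen on the aromatic ring gives a 1.1-fold lower number from compound 3 to compound 4 (0.05 log units; within the scatter), so in this read-out acetoxy and hydroxy cannot be told apart at this place. With hydroxy on that oxygen, 3-methoxyphenyl on the aromatic carbon can now be compared with two smaller groups: exchanging chloro for it gives a 1.8-fold lower number from compound 2 to compound 4 (0.26 log units; within the scatter), and exchanging allyl for it gives a 2.7-fold lower number from compound 1 to compound 4 (0.43 log units; beyond the scatter), a modest step and the only one of the three beyond the scatter. Nothing measured here gives a reason for these numbers.

As far as these compounds go, whether a methyl ether or a longer ester on that oxygen would also leave the number within the scatter stays open. So does the effect of an amine or a carboxylic acid on the aromatic carbon.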